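Swapping an Anilide for a Benzylamide in Compound 2

A few compounds are considered here, and "the series" means these few. Any claim that something is new, unique, unknown or untested is made for them only; others in the source may bear on it.

Compound 1 `COc1cc(-c2nnc(SCC(=O)c3ccc(C)cc3)n2N)cc(OC)c1OC` gives 31300 nM in a functional assay on PC-3 cells (Homo sapiens) for antiproliferative activity, read by MTT assay, with a stated time of 48 h; a higher number here means a weaker inhibitor, a lower number a stronger inhibitor. Compound 2 `COc1cccc(NC(=O)CSc2nnc(-c3cc(OC)c(OC)c(OC)c3)n2N)c1` reports only a limit, > 100000 nM, in this assay. The step of an at least 3.1-fold higher number from compound 1 to compound 2 (0.50 log units; beyond the scatter) is thus at least modest. Compound 3 `COc1cc(-c2nnc(SCC(=O)NCc3ccc(C)cc3)n2N)cc(OC)c1OC` differs from compound 2 by 4-methylbenzyl in place of 3-methoxyphenyl on an amide-type nitrogen. Within the data shown here, only one measured step bears on this change, and it ends at the assay limit of > 100000 nM in this assay, at which 1 of the 2 values shown sits, rather than at a number. Because compound 1 with its 4-methylphenyl group gives 31300 nM, compound 3 is expected to fall between the two, with an at least 1.4-fold lower number from compound 2 to compound 3 (0.15 log units; that floor lies within the scatter). Compound 3 is therefore estimated at 70000 nM, within 20000 nM to 200000 nM.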

Compound 3, half-maximal inhibitory concentration: 92800 nM
The estimate for compound 3 lay 1.3-fold (0.12 log units) below the measured number, within the range that was stated.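

Compound 3 gives the amide series its first real number, and it shows that (4-methylbenzyl)amino on the carbonyl carbon costs modestly against 4-methylphenyl (a 3.0-fold higher number from compound 1 to compound 3 (0.47 log units; beyond the scatter)). Between the two amides no order can be claimed (an at least 1.0-fold lower number from compound 2 to compound 3 (0.03 log units; that floor lies within the scatter)). Compound 2 is held at a limit of the assay, not a number: the limit of > 100000 nM in this assay, at which 1 of the 3 values shown sits.

Still open, on these data alone, is whether a longer chain on the amide-type nitrogen, such as 2-phenylethyl, or an amine on the benzyl ring would change the picture.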